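This account rests on a few compounds, and the source may have more. Where it says the series, first, only, none or still open, it means among the compounds named here.

Measured so far in an ADME assay on HepG2 2.2.15 cells (Homo sapiens) for cytotoxicity; a higher number here means that more compound is tolerated, a lower number that less compound is tolerated:
- Compound 1 `O=C(CCC1CCCCC1)OCCc1c(-c2ccccc2Cl)c2cc(Cl)ccc2[nH]c1=O`: 160000 nM
- Compound 2 `O=C(/C=C/c1ccccc1)OCCc1c(-c2ccccc2Cl)c2cc(Cl)ccc2[nH]c1=O`: 230000 nM

Not yet measured:
- Compound 3 `COc1ccccc1/C=C/C(=O)OCCc1c(-c2ccccc2Cl)c2cc(Cl)ccc2[nH]c1=O`

In this assay, for the measured compounds named here, compound 2 gives 230000 nM, and compound 1 is its only neighbour on the scale. The step between them is a 1.4-fold higher number from compound 1 to compound 2 (0.16 log units; within the scatter), so the two compounds cannot be told apart on these numbers.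

Compound 3 keeps all of compound 2 except for one change on the phenyl ring of the 2-phenylethenyl group, which becomes 2-(2-methoxyphenyl)ethenyl. The difference is methoxy in place of hydrogen on an aromatic carbon, ortho to a large group.

Going by the values given here, no measured step tests this replacement directly. The nearest evidence is the exchange of 2-cyclohexylethyl for 2-phenylethenyl on a carbonyl carbon, which gave a 1.4-fold higher number from compound 1 to compound 2 (0.16 log units; within the scatter). With so small a change from that larger exchange, no shift beyond the scatter is expected here, in either direction, though a single step is thin support.

The estimated step is a 1.2-fold lower number from compound 2 to compound 3 (0.06 log units; within the scatter). For compound 3 the expected value is 200000 nM, with an estimated range of 100000 nM to 400000 nM.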

Compound 3, half-maximal cytotoxic concentration: 770000 nM
Beside the measured number, compound 3's estimate is 3.9-fold (0.59 log units) below it; the whole stated range lies below it.
By their numbers in this assay, from the lowest: compounds 1 and 2 (each within the scatter of the next); then compound 3.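

In this assay, the phenyl ring of the 2-phenylethenyl group proves to be a place where a single substitution can register: methoxy in place of hydrogen on an aromatic carbon, ortho to a large group, gives a 3.3-fold higher number from compound 2 to compound 3 (0.52 log units; beyond the scatter) and so moves the number beyond the scatter, which the earlier exchange on the carbonyl carbon did not do. Against the other side chain, 2-(2-methoxyphenyl)ethenyl in place of 2-cyclohexylethyl gives a 4.8-fold higher number from compound 1 to compound 3 (0.68 log units; beyond the scatter) and so compound 3 stands apart from both earlier compounds, which cannot be told apart from each other. Nothing measured here accounts for this shift.

The compounds shown leave open whether the higher number belongs to methoxy itself or would also follow from another group on the same aromatic carbon, such as ethoxy, hydroxy, fluorine or an amine. They also leave open whether methoxy on another carbon of that ring would give a similar step, and whether it would do so on a ring carried by a longer chain.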